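The source may report more compounds than this note shows. Statements on the series, on what has been measured and on what is new or still open speak of the compounds shown alone.

Compound 1 `CS(=O)(=O)NC1CN(CC2CCN(Cc3ccccc3)CC2)C(=O)N(c2cccc(C(=N)N)c2)C1` gives 420 nM in an assay on isolated protein for inhibition of Trypsin (Homo sapiens), read by fluorescence; a lower number here means a stronger inhibitor, a higher number a weaker inhibitor. Among the measured compounds shown here, compound 2 `N=C(N)c1cccc(N2CC(OCc3ccccc3)CN(CC3CCN(Cc4ccccc4)CC3)C2=O)c1` gives 550 nM in this assay, the higher of the two numbers so far, though the step of a 1.3-fold higher number from compound 1 to compound 2 (0.12 log units; within the scatter) is within the scatter. Compound 3 `COCC1CN(CC2CCN(Cc3ccccc3)CC2)C(=O)N(c2cccc(C(=N)N)c2)C1` differs from compound 2 by methoxymethyl in place of benzyloxy on a saturated ring carbon. For the measured compounds named here, the only step that bears on this site, a 1.3-fold higher number from compound 1 to compound 2 (0.12 log units; within the scatter), swapped the same substituent and moved the number little, so no change beyond the scatter is expected, and the step of no change at the digits printed from compound 2 to compound 3 (within the scatter) is estimated accordingly. For compound 3 the expected value is 550 nM, with a range from 200 nM to 1500 nM.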

Compound 3, inhibition constant in the Trypsin assay: 210 nM
Estimate against measurement, compound 3: 2.6-fold (0.42 log units) above, and the stated range covers the measured number.
By their numbers in the Trypsin assay, from the lowest: compounds 3, 1 and 2 (each within the scatter of the next, the first and the last beyond it).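

Among the compounds shown here, in the Trypsin assay this ring carbon now shows that its substituent can matter: compound 2 gives 550 nM and compound 3 gives 210 nM, so methoxymethyl in place of benzyloxy gives a 2.6-fold lower number from compound 2 to compound 3 (0.42 log units; beyond the scatter), the only step so far beyond the scatter, while methoxymethyl in place of methanesulfonamido gives a 2.0-fold lower number from compound 1 to compound 3 (0.30 log units; within the scatter). In a physicochemical assay for solubility, measured as kinetic solubility, at pH 7.4 (on this read-out higher numbers stand for higher solubility and lower numbers for lower solubility), compound 2 gives 47000 nM and compound 3 gives 47000 nM, so the same change from benzyloxy gives no change at the digits printed from compound 2 to compound 3 (within the scatter), and only the Trypsin assay separates the two groups. Nothing given here accounts for the step. On these data alone, whether an amine or a carboxylic acid at this ring carbon would shift the number in the Trypsin assay remains open, as does the effect of a longer ether chain.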